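This account rests on a few compounds, and the source may have more. Where it says the series, first, only, none or still open, it means among the compounds named here.

Measured compounds in a functional assay on MEL28 cells (Homo sapiens) for cytotoxicity, read by sulforhodamine B assay, with a stated time of 72 h; on this read-out higher numbers stand for weaker inhibition of growth and lower numbers for stronger inhibition of growth:
compound 1 `C=C1CC[C@@H]2[C@](C)(CCC[C@]2(C)C(=O)OC)[C@H]1CCc1ccc2c(OC)ccc(OC)c2c1` gives > 6700 nM, which is a limit of this assay rather than a number.
compound 2 `C=C1CC[C@@H]2[C@](C)(CCC[C@]2(C)C(=O)OC)[C@H]1CCc1ccc2c(OCc3ccccc3)ccc(OCc3ccccc3)c2c1` gives > 5000 nM, again a limit and not a number.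
compound 3 `C=C1[C@H](O)C[C@@H]2[C@](C)(CCC[C@]2(C)C(=O)OC)[C@H]1CCc1ccc2c(OC)ccc(OC)c2c1` gives > 6400 nM, also a limit and not a number.

Compound 3 comes from compound 1 by one change, (hydroxy in place of hydrogen on a saturated ring carbon), and the step that the two limits leave unreadable from compound 1 to compound 3 is unreadable: both ends sit at limits of this assay, so nothing can be said about its size or direction. Compound 2 and compound 1 share the same change-free relationship to their own partners, but the difference between the two cores is not broken down here; the two values for compound 1 and compound 2 show only that each lies at a limit, as the limit of > 6700 nM in this assay, at which 1 of the 3 values shown sits, and the limit of > 5000 nM in this assay, at which 1 of the 3 values shown sits, record. The same holds for compound 3 at the limit of > 6400 nM in this assay, at which 1 of the 3 values shown sits.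

Compound 4 `C=C1[C@H](O)C[C@@H]2[C@](C)(CCC[C@]2(C)C(=O)OC)[C@H]1CCc1ccc2c(OCc3ccccc3)ccc(OCc3ccccc3)c2c1` is not yet measured. It stands to compound 2 as compound 3 stands to compound 1: the change hydroxy in place of hydrogen on a saturated ring carbon is the same, made at the same place on the same kind of ring. Since the measured pair compound 1 to compound 3 gives no readable step, the expected step that the limit leaves unreadable from compound 2 to compound 4 in this assay is estimated to be flat, with all three measured values resting at limits. Compound 4 is therefore expected to fall at about 9000 nM, most likely reported again as a limit, with a plausible range of 3000 nM to 40000 nM.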

Compound 4, concentration for 50% growth inhibition: > 4900 nM
Compound 4: no number, only a limit (the forecaster's own chance of this, stated with the estimate: 85%); the middle value is on the limit's open side.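

In this assay compound 4 gives > 4900 nM, which is a limit and not a number. Compound 2 gives > 5000 nM, also a limit, so the step between compound 2 and compound 4 cannot be read. The compounds shown leave open how strongly any of the four inhibits growth, and whether hydroxy in place of hydrogen on a saturated ring carbon alters that inhibition at all.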